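The compounds below may be only part of what the source reports. "The series", "measured", "known", "first", "only" and "open" are said of these compounds alone.

Compound 1 `CC(C)=CCc1cc(C(=O)Nc2cc3ccc(OCCC4CCCCN4)c(C)c3oc2=O)ccc1O` is the starting point of this account. In a functional assay on SK-BR-3 cells (Homo sapiens) for antiproliferative activity (on this read-out higher numbers stand for weaker inhibition and lower numbers for stronger inhibition), compound 1 gives 640 nM, and on the numbers shown it stands alongside compound 2 `CCN(C)CCCOc1ccc2cc(NC(=O)c3ccc(O)c(CC=C(C)C)c3)c(=O)oc2c1C`, the only other measured compound, which in this assay gives 730 nM; the gap between the two, a 1.1-fold higher number from compound 1 to compound 2 (0.06 log units; within the scatter), lies within the scatter. Compound 3 `CC(C)=CCc1cc(C(=O)Nc2cc3ccc(OCCCNc4ccccc4)c(C)c3oc2=O)ccc1O` has not yet been measured. It differs from compound 1 in one place: anilinomethyl in place of piperidin-2-yl on a saturated chain carbon, two bonds along the chain from an oxygen on an aromatic ring. Among the measured compounds shown here, only one measured step bears on this change, the one from compound 1 to compound 2, in which the same piperidin-2-yl was exchanged for (ethyl(methyl)amino)methyl at the same place and the number moved a 1.1-fold higher number from compound 1 to compound 2 (0.06 log units; within the scatter). For the measured compounds named here, that step shows that exchanging the piperidin-2-yl for another nitrogen-bearing group at this position leaves the result nearly unchanged; anilinomethyl, with its aromatic ring, is a further departure for which no measured step exists. Compound 3 is therefore expected to give 900 nM, with a range of 350 nM to 2500 nM. The expected step from compound 1 is a 1.4-fold higher number from compound 1 to compound 3 (0.15 log units; within the scatter).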

Compound 3, half-maximal inhibitory concentration: > 50000 nM
Compound 3: a limit, no number (the forecaster's own chance of this, stated with the estimate: 3%); at least 55-fold (1.74 log units) between middle value and limit.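

In this assay compound 3 stands at a limit of the assay and not at a number: the limit of > 50000 nM in this assay, at which 1 of the 3 values shown sits. Set against that limit, the exchange of piperidin-2-yl for anilinomethyl brings an at least 78-fold higher number from compound 1 to compound 3 (1.89 log units; beyond the scatter), and the exchange of ethyl(methyl)amino for anilino brings an at least 68-fold higher number from compound 2 to compound 3 (1.83 log units; beyond the scatter), so the two nitrogen-bearing groups that lay within the scatter of each other do not speak for every such group at this place. The position, on a saturated chain carbon, two bonds along the chain from an oxygen on an aromatic ring, therefore accepts piperidin-2-yl and (ethyl(methyl)amino)methyl but not anilinomethyl in this series.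

The compounds shown leave open whether the drop goes with the aromatic ring as such or with that ring sitting directly on the nitrogen, a question that a benzylamino or a cyclohexylamino group in the same place would address. They also leave open how far past its limit compound 3 lies, and whether a methoxy or a fluoro group on the anilino ring would change the result.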